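Shortening the ring-nitrogen substituent of compound 1

The source may hold more compounds than are shown below. What is called first, only, known or untested is meant among the compounds shown, and "the series" means these compounds.

Compound 1 `Cc1c(Nc2nc(N)c3c(C#N)c(N4CCC[C@H]4C)n(C)c3n2)cnn1CC(C)(C)O` gives the lowest number of the two measured compounds. In an assay on isolated protein for inhibition of Leucine-rich repeat serine/threonine-protein kinase 2 (Homo sapiens), read by TR-FRET and LanthaScreen, with stated times of 50 min and 30 min, in the presence of a further agent that is not named here (on this read-out higher numbers stand for weaker inhibition and lower numbers for stronger inhibition), compound 1 gives 43 nM. Going by the values given here, compound 2 `Cc1cn(C)nc1Nc1cc2c(c(N)n1)c(C#N)c(N1CCC[C@H]1C)n2C`, which carries the amine link and the ring methyl groups in a different arrangement on the shared core, gives 2110 nM in this assay, a number far beyond the scatter from that of compound 1; no single-point step joins the two, so only the two values themselves can be compared.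

Compound 3 `Cc1c(Nc2nc(N)c3c(C#N)c(N4CCC[C@H]4C)n(C)c3n2)cnn1C` differs from compound 1 at one place: hydrogen in place of 1-hydroxy-1-methylethyl on a saturated chain carbon bound to an aromatic nitrogen. Among the compounds with values here, no measured pair shows this kind of change, so its size is not known from the data. Compound 2 tells nothing about it, since its change lies elsewhere. The expectation is a small loss of potency from compound 1 to compound 3, at the edge of the scatter or slightly beyond it, as a 2.6-fold higher number from compound 1 to compound 3 (0.41 log units; beyond the scatter). Compound 3 is therefore estimated at 110 nM in this assay, with a plausible range from 35 nM to 350 nM.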

Compound 3, half-maximal inhibitory concentration: 75 nM
Compound 3: the middle estimate sits 1.5-fold (0.17 log units) above what was measured; the measured number falls inside the stated range.
By their numbers in this assay, from the lowest: compounds 1 and 3 (each within the scatter of the next); then compound 2.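

Going by these compounds alone, this is the first single-place step, and in this assay it reads a 1.7-fold higher number from compound 1 to compound 3 (0.24 log units; within the scatter). At this position, on a saturated chain carbon bound to an aromatic nitrogen, 1-hydroxy-1-methylethyl can therefore give way to hydrogen, cutting 2-hydroxy-2-methylpropyl back to methyl, with no difference beyond the scatter, even though the group that leaves carries 4 heavy atoms, 1 hydrogen-bond donor and 1 hydrogen-bond acceptor. No supporting data on hand bear on why the two numbers stay this close.

Going by these compounds, this single pair defines only two points at this position, so it remains open whether a carboxylic acid, a dimethylamino group or a longer chain such as 3-hydroxy-3-methylbutyl in place of 2-hydroxy-2-methylpropyl would also stay within the scatter of compound 1 or would move clearly away from it. Also open, on these data alone, is whether the closeness of compound 1 and compound 3 carries over to any read-out other than this assay, such as a test in whole cells.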